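The compounds below may be only part of what the source reports. "The series", "measured", "known", "first", "only" and "open" are said of these compounds alone.

Working notes on the series, read in a physicochemical assay for lipophilicity, measured as octanol-water partition; on this read-out higher numbers stand for higher lipophilicity and lower numbers for lower lipophilicity. The measured compounds share one core and differ in the group on a carbon with a double bond to nitrogen. Compound 1 (`O=C(NNc1ccnc2cc(Cl)ccc12)c1ccccc1/N=C/c1ccccc1Cl`) gives 5.5, compound 2 (`O=C(NNc1ccnc2cc(Cl)ccc12)c1ccccc1/N=C/c1ccc(Br)cc1`) gives 5.76 and compound 3 (`O=C(NNc1ccnc2cc(Cl)ccc12)c1ccccc1/N=C/c1ccc([N+](=O)[O-])cc1`) gives 4.58. The lowest of the three numbers belongs to compound 3. The two steps leading down to it are a number 0.92 log units lower from compound 1 to compound 3 (beyond the scatter) and a number 1.18 log units lower from compound 2 to compound 3 (beyond the scatter), while the remaining step, a number 0.26 log units higher from compound 1 to compound 2 (within the scatter), stays within the scatter.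

Compound 4 (`O=C(NNc1ccnc2cc(Cl)ccc12)c1ccccc1/N=C/c1cc2ccccc2nc1Cl`) is next, and the change is 2-chloroquinolin-3-yl in place of 4-nitrophenyl on a carbon with a double bond to nitrogen. In words, this is 2-chloroquinolin-3-yl in place of 4-nitrophenyl on a carbon with a double bond to nitrogen.

Within the data shown here, no measured compound carries 2-chloroquinolin-3-yl, so the size of the step has no direct precedent. Among the measured compounds shown here, the nearest guide is that both steps beyond the scatter, a number 0.92 log units lower from compound 1 to compound 3 (beyond the scatter) and a number 1.18 log units lower from compound 2 to compound 3 (beyond the scatter), end at the one compound holding 4-nitrophenyl. Compound 4 gives up that group, so in this assay a step upward of similar size is expected, beyond the scatter. The expected step is a number 1.12 log units higher from compound 3 to compound 4 (beyond the scatter). For compound 4 the estimated value is 5.7, with an expected range of 5.1 to 6.3.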

Compound 4, partition coefficient: 6
Estimate against measurement, compound 4: 0.30 log units below; the range from low to high includes it.
By their numbers in this assay, from the lowest: compound 3; then compounds 1, 2 and 4 (each within the scatter of the next, the first and the last beyond it).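

In this assay, among these compounds, compound 4 shows that the carbon with a double bond to nitrogen can carry a group of two six-membered aromatic rings, one of them with 1 hetero atom, whereas the earlier compounds held only one ring of carbon there. Among the compounds shown here, the step of a number 1.42 log units higher from compound 3 to compound 4 (beyond the scatter) leaves compound 3, the one compound with 4-nitrophenyl, apart from all three others, and the step of a number 0.50 log units higher from compound 1 to compound 4 (beyond the scatter) separates 2-chloroquinolin-3-yl from 2-chlorophenyl, while the step of a number 0.24 log units higher from compound 2 to compound 4 (within the scatter) does not separate it from 4-bromophenyl. Nothing available gives a measured property that would account for these steps on this carbon.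

The change to 2-chloroquinolin-3-yl alters the ring system and brings in chlorine together, so the compounds shown cannot assign the step to either part, and quinolin-3-yl without the chlorine would be needed to divide them. Also open, on these data alone, is whether 4-nitrophenyl is unusual or whether a phenyl ring bearing an amine or a carboxylic acid would give a number as low as that of compound 3 or lower.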